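This account rests on a few compounds, and the source may have more. Where it says the series, first, only, none or still open, it means among the compounds named here.

Measured in a functional assay on MCF7 cells (Homo sapiens) for antiproliferative activity, read by luminescence and CellTiter-Glo, with a stated time of 48 h; on this read-out higher numbers stand for weaker inhibition and lower numbers for stronger inhibition:
compound 1 `O=C1C=CC[C@@H](/C=C/C2CCCCC2)O1`: > 100000 nM
compound 2 `COc1ccc(/C=C/[C@H]2CC=CC(=O)O2)cc1`: > 100000 nM

Compound 2 gives only a limit of this assay, > 100000 nM, and not a number. Among the measured compounds shown here, no compound yet has a number, and the series so far is summed up as the limit of > 100000 nM in this assay, at which 2 of the 2 values shown sit.

Compound 3 `O=C1C=CC[C@H](/C=C/c2ccc([N+](=O)[O-])cc2)O1` follows from compound 2 by one change: nitro in place of methoxy on an aromatic carbon. The methoxy group of compound 2 is gone, and a nitro group sits at its place.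

For the measured compounds named here, no measured step shows what such a change does. A small step toward stronger inhibition in this assay is expected, possibly none beyond the scatter. This expectation rests on compound 2, whose > 100000 nM is a limit. Another limit would be no surprise.

The estimated step is an at least 1.2-fold lower number from compound 2 to compound 3 (0.09 log units; that floor lies within the scatter). For compound 3 the expected value is 80000 nM, with an estimated range of 20000 nM to 200000 nM.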

Compound 3, half-maximal inhibitory concentration: 28800 nM
For compound 3 the middle estimate is 2.8-fold (0.44 log units) above the measured one; the range from low to high includes it.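

Among the compounds shown here, compound 3 is the first compound to give a number rather than a limit in this assay, at 28800 nM, so this position on the aromatic ring now has a measurable read-out. Nitro in place of methoxy on this aromatic carbon, para to a group of 9 heavy atoms, gives an at least 3.4-fold lower number from compound 2 to compound 3 (0.54 log units; beyond the scatter); this is a floor on a step beyond the scatter, and its full size stays unknown as it starts from a limit. The rest of the series gives no number to set beside it: the limit of > 100000 nM in this assay, at which 2 of the 3 values shown sit.

On these data alone, whether the lower number is particular to nitro stays open, as no other group at this position, such as an amine, a carboxylic acid or a nitrile, appears here. With one step, the series also cannot show a trend, nor what nitro would do at another carbon of the ring.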